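A few compounds are considered here, and "the series" means these few. Any claim that something is new, unique, unknown or untested is made for them only; others in the source may bear on it.

Working notes on the series.

The measured set is small. Compound 1 `CNC(=O)c1cc(C(=O)NC2CC2)cn(CC2CCCOC2)c1=O` gives 2 in a physicochemical assay for lipophilicity, at pH 7.4 (on this read-out lower numbers stand for lower lipophilicity and higher numbers for higher lipophilicity), the lowest of the three numbers. Compound 2 `CNC(=O)c1ccc(=O)n(Cc2cc(Br)ccc2F)c1` gives 2.6 in this assay, which is beyond the scatter from compound 1; compound 3 `CNC(=O)c1cccn(Cc2ccccc2)c1=O` gives 3 in this assay, the furthest from compound 1 and also beyond the scatter. Among the measured compounds shown here, no two of the measured compounds differ in a single place, so no step between them can be read as a clean change.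

Compound 4 `CNC(=O)c1cc(C(=O)NC2CC2)cn(Cc2nccc3[nH]ccc23)c1=O` has not been measured in this assay. It differs from compound 1 in this way: a group of 9 heavy atoms (7 carbon, 2 nitrogen; one five-membered aromatic ring with 1 hetero atom, one six-membered aromatic ring with 1 hetero atom) in place of a group of 6 heavy atoms (5 carbon, 1 oxygen; one six-membered non-aromatic ring with 1 hetero atom), on a saturated chain carbon bound to an aromatic nitrogen. The group that leaves carries one hydrogen-bond acceptor and no donor; the group that enters carries one donor and one acceptor and two aromatic rings. In the absence of a matched step among the measured compounds, the change is expected to move the number only a little, with a step of a number 0.10 log units higher from compound 1 to compound 4 (within the scatter) from compound 1 to compound 4 that stays within the scatter. For compound 4 the estimate is 2.1, expected between 1.5 and 2.7.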

Compound 4, distribution coefficient: 1.7
Estimate against measurement, compound 4: 0.40 log units above; the range from low to high includes it.
By their numbers in this assay, from the lowest: compounds 4 and 1 (each within the scatter of the next); then compound 2; then compound 3.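

Among the compounds shown here, this is the first step at this position that can be read in this assay: on a saturated chain carbon bound to an aromatic nitrogen, the group of 9 heavy atoms with its two aromatic rings and one hydrogen-bond donor replaces oxan-3-yl, giving a number 0.30 log units lower from compound 1 to compound 4 (within the scatter) in a single change. At this place, then, a larger entering group with a different ring count and a donor leaves the number of the shared core within the scatter. No measurement at hand accounts for this result.

This single step leaves open whether an amine or a carboxylic acid at the same place would move the number beyond the scatter. From the compounds shown here alone, a longer chain carrying the same group also remains untested in these compounds, and so does any other change on the core of compound 1.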